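Methyl to Ethyl on the Amide Nitrogen: Compound 4

The compounds below may be only part of what the source reports. "The series", "measured", "known", "first", "only" and "open" are said of these compounds alone.

Of the compounds shown here, three that share one core have been measured. Compound 1 `CN1C(=O)CN(C2CCCC2)c2nc(Nc3ccc(N4CCCCC4)cc3)ncc21` gives 21200 nM in a functional assay on MDA-MB-231 cells (Homo sapiens) for inhibition, read by MTT assay, with a stated time of 48 h; a higher number here means a weaker inhibitor, a lower number a stronger inhibitor. Compound 2 `CN1C(=O)CN(C2CCCC2)c2nc(Nc3ccc(N4CCCCC4)cn3)ncc21` gives 29300 nM in this assay. Compound 3 `CC1CCN(c2ccc(Nc3ncc4c(n3)N(C3CCCC3)CC(=O)N4C)nc2)CC1` gives only > 30000 nM in this assay, which is a limit of the assay and not a number. Compound 3 therefore sits at the limit of > 30000 nM in this assay, at which 1 of the 3 values shown sits. Within the data shown here, the one measured step that differs in a single place, a methyl added on a saturated ring carbon, reads an at least 1.0-fold higher number from compound 2 to compound 3 (0.01 log units; that floor lies within the scatter) and lies within the scatter.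

Compound 4 `CCN1C(=O)CN(C2CCCC2)c2nc(Nc3ccc(N4CCC(C)CC4)cn3)ncc21` differs from compound 3 by methyl in place of hydrogen on a saturated chain carbon bound to an amide-type nitrogen in a ring. Among the measured compounds shown here, no measured step touches a saturated chain carbon bound to an amide-type nitrogen in a ring, so the only comparable evidence is the small added methyl of an at least 1.0-fold higher number from compound 2 to compound 3 (0.01 log units; that floor lies within the scatter), which changed nothing beyond the scatter. On that basis no step beyond the scatter is expected in this assay for compound 4, and since compound 3 stands at a limit, compound 4 may well return a limit again. Compound 4 is expected to give about 35000 nM in this assay, with a range from 15000 nM to 80000 nM. The expected step is a step that the limit leaves unreadable from compound 3 to compound 4.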

Compound 4, half-maximal inhibitory concentration: > 30000 nM
Compound 4: no number, only a limit; the forecaster's own chance of this, stated with the estimate: 60%; the middle value is on the limit's open side.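

In this assay compound 4 gives > 30000 nM and this is a limit of the assay, not a number. Compound 3 also stands at a limit, so no step can be read from compound 3 to compound 4. The compounds shown leave open whether methyl to ethyl changes inhibition at all. Compound 3 and compound 4 share one limit: the limit of > 30000 nM in this assay, at which 2 of the 4 values shown sit.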